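A few compounds are considered here, and "the series" means these few. Any claim that something is new, unique, unknown or untested is made for them only; others in the source may bear on it.

Measured so far: compound 1 `NCCn1cc(C(=O)c2ccn3c2CSC3c2cccnc2)c2ccc(-c3ccc(F)cc3)cc21` and compound 2 `O=C(O)CCn1cc(C(=O)c2ccn3c2CSC3c2cccnc2)c2ccc(-c3ccc(F)cc3)cc21`. In a functional assay (Oryctolagus cuniculus) for antagonist activity at platelet-activating factor receptor (Cavia porcellus) (a higher number here means a weaker inhibitor, a lower number a stronger inhibitor), compound 1 gives 38 nM. In this assay compound 2 gives 160 nM.

Among the measured compounds shown here, compound 2 thus holds the higher of the two numbers, the other belonging to compound 1; the single measured step, a 4.2-fold higher number from compound 1 to compound 2 (0.62 log units; beyond the scatter), separates them. Compound 3 `NNC(=O)n1cc(C(=O)c2ccn3c2CSC3c2cccnc2)c2ccc(-c3ccc(F)cc3)cc21` differs from compound 2 by aminocarbamoyl in place of 2-carboxyethyl on an aromatic nitrogen. For the measured compounds named here, only that one step bears on this change, and it shows the carboxy-bearing chain at the same aromatic nitrogen with the higher number. Replacing it is therefore expected to give a modest step downward, a 2.0-fold lower number from compound 2 to compound 3 (0.30 log units; within the scatter). Compound 3 is estimated at 80 nM, with a range from 25 nM to 250 nM.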

Compound 3, inhibition constant: 25 nM
Estimate against measurement, compound 3: 3.2-fold (0.51 log units) above; the measured number falls inside the stated range.
By their numbers in this assay, from the lowest: compounds 3 and 1 (each within the scatter of the next); then compound 2.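

In this assay, aminocarbamoyl on the aromatic nitrogen gives a 6.4-fold lower number from compound 2 to compound 3 (0.81 log units; beyond the scatter), so this position accepts a group other than a saturated chain. Against 2-aminoethyl, the change gives a 1.5-fold lower number from compound 1 to compound 3 (0.18 log units; within the scatter) and leaves these two groups unseparated, with only the 2-carboxyethyl compound standing apart from both. No available evidence bears on the origin of these steps.

From the compounds shown here alone, it remains open whether a plain carbamoyl group, without the terminal amino group, would read like aminocarbamoyl. A longer aminoalkyl chain or a simple methyl group at this nitrogen is also untested in the compounds shown.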